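Methoxyphenyl in place of methylphenyl on the urea nitrogen

This account rests on a few compounds, and the source may have more. Where it says the series, first, only, none or still open, it means among the compounds named here.

compound 1, `Cc1ccccc1NC(=O)Nn1c(C)nc2ccccc2c1=O`: 51%
compound 2, `Cc1cccc(NC(=O)Nn2c(C)nc3ccccc3c2=O)c1`: 51%

In a functional assay on the whole organism for inhibition, with Mus musculus as the target, with a stated time of 1 h, at a dose of 100 mg/kg by the intraperitoneal route (a higher number here means more inhibition at the dose given (going by the name of the read-out), a lower number less inhibition), compound 1 gives 51% and compound 2 gives 51%, so compound 2 stands level with compound 1: the step of no change at the digits printed from compound 1 to compound 2 (within the scatter) stayed within the scatter. Compound 3, `COc1ccc(NC(=O)Nn2c(C)nc3ccccc3c2=O)cc1`, differs from compound 2 in one place: 4-methoxyphenyl in place of 3-methylphenyl on an amide-type nitrogen. For the measured compounds named here, the only measured step, moving a methyl group around the phenyl ring, gave no change; no measured step covers a methoxy group, so the expectation is a step of about a number 1 percentage points lower from compound 2 to compound 3 (within the scatter), none beyond the scatter. Compound 3 is therefore estimated at 50%, between 35% and 65%.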

Compound 3, a percentage reported as inhibition, in the whole organism at one dose (the size of the read-out at that dose, not a potency): 42%
Estimate against measurement, compound 3: 8 percentage points above; the measured number falls inside the stated range.
By their numbers in this assay, from the lowest: compounds 3, 1 and 2 (each within the scatter of the next).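

In this assay, putting 4-methoxyphenyl on the amide-type nitrogen gives a number 9 percentage points lower from compound 2 to compound 3 (within the scatter) and a number 9 percentage points lower from compound 1 to compound 3 (within the scatter) in the two comparisons. The earlier pair only moved a methyl group around the ring, whereas this change brings in an oxygen and a hydrogen-bond acceptor without a difference that stands clear of the scatter. Nothing available here explains the result.

Still open, going by these compounds, is how a carboxylic acid or a dimethylamino group on the phenyl ring would read in this assay at this position. A 4-methylphenyl group would also allow a direct comparison of methyl and methoxy at the same ring position.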